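The source may hold more compounds than are shown below. What is called first, only, known or untested is meant among the compounds shown, and "the series" means these compounds.

Measured so far in a physicochemical assay for solubility, read by LC-MS, in phosphate buffer, measured as thermodynamic solubility, with a stated time of 24 h, at pH 7.4; on this read-out lower numbers stand for lower solubility and higher numbers for higher solubility:
- compound 1 `N#Cc1cccc(-c2c[nH]c3ncc(-c4ccncc4)cc23)c1`: 200 nM
- compound 2 `CC(C)(C)OC(=O)N1CCN(c2cnc3[nH]cc(-c4cccc(C#N)c4)c3c2)CC1`: 12000 nM

Among the measured compounds shown here, only two numbers are available, and compound 1 has the lower one. At 200 nM, compound 1 lies well under compound 2 at 12000 nM, and this gap is larger than the usual scatter of repeated measurements.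

The next compound to be tested is compound 3 `Cn1cc(Nc2cnc3[nH]cc(-c4cccc(C#N)c4)c3c2)cn1`. It keeps the shared core of compound 1 but has (1-methyl-1H-pyrazol-4-yl)amino in place of pyridin-4-yl on an aromatic carbon of a six-membered aromatic ring with 1 nitrogen: (1-methyl-1H-pyrazol-4-yl)amino in place of pyridin-4-yl on an aromatic carbon.

For the measured compounds named here, no measured pair shows this exact change, so any forecast is loose. Going by the values given here, the one guide is that compound 2 reaches 12000 nM, which shows that numbers far higher than that of compound 1 occur in this small set. A moderate rise beyond the scatter therefore seems the likeliest outcome, and the expected step is a 7.5-fold higher number from compound 1 to compound 3 (0.88 log units; beyond the scatter). In this assay, the estimated value for compound 3 is 1500 nM, with an expected range from 300 nM to 9000 nM.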

Compound 3, solubility: 31000 nM
The estimate for compound 3 lay 21-fold (1.32 log units) below the measured number, outside the stated range (above it).
By their numbers in this assay, from the lowest: compound 1; then compound 2; then compound 3.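

In this assay, the aromatic carbon that carries the changing group turns out to be highly sensitive to the group placed there: (1-methyl-1H-pyrazol-4-yl)amino in place of pyridin-4-yl gives a 160-fold higher number from compound 1 to compound 3 (2.19 log units; beyond the scatter), a large step on the shared core. This single exchange alters several things together, as a six-membered aromatic ring with 1 hetero atom leaves and a five-membered aromatic ring with 2 hetero atoms enters, joined through an amino link that brings 1 hydrogen-bond donor, while the acceptor count goes from 1 to 3. Nothing measured here ties the step to any one of these differences or explains it.

The compounds shown leave open whether the five-membered ring or the amino link carries the step. A 1-methyl-1H-pyrazol-4-yl group attached directly to the same aromatic carbon, or a phenylamino group placed there, would begin to separate those two parts of the change.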